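The source may report more compounds than this note shows. Statements on the series, on what has been measured and on what is new or still open speak of the compounds shown alone.

Measured in an ADME assay on liver (Homo sapiens) for metabolic stability, using microsomes; on this read-out higher numbers stand for a longer-lived compound and lower numbers for a shorter-lived compound:

- compound 1 `C=C(C)[C@@H]1C[C@]1(NC(=O)[C@@H]1C[C@@H](Oc2ncc(OC)c3ccc(Cl)cc23)CN1C(=O)[C@@H](NC(=O)OC(C)(C)C)C(C)(C)C)C(=O)NS(=O)(=O)C1CC1`: 0.0833 h
- compound 2 `COc1cnc(O[C@@H]2C[C@@H](C(=O)N[C@]3(C(=O)NS(=O)(=O)C4CC4)C[C@H]3C3CC3)N(C(=O)[C@@H](NC(=O)OC(C)C)C(C)(C)C)C2)c2cc(Cl)ccc12`: 0.583 h

Only these two compounds have been measured so far. Compound 2 stands higher at 0.583 h, and compound 1 lies lower at 0.0833 h, a gap beyond the usual scatter. The two structures differ in more than one place, so this gap cannot be tied to any single change.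

Compound 3 `COc1cnc(O[C@@H]2C[C@@H](C(=O)N[C@]3(C(=O)NS(=O)(=O)C4CC4)C[C@H]3C3CC3)N(C(=O)[C@@H](NC(=O)OC(C)(C)C(F)(F)F)C(C)(C)C)C2)c2cc(Cl)ccc12` is derived from compound 2 by one change: trifluoromethyl in place of hydrogen on a saturated chain carbon bound to an oxygen next to a carbonyl group and two saturated chain carbons. A trifluoromethyl group replaces hydrogen on a saturated chain carbon bound to an oxygen next to a carbonyl group and two saturated chain carbons, so isopropoxycarbonyl becomes (1-methyl-1-(trifluoromethyl)ethoxy)carbonyl.

Among the compounds with values here, no measured pair shows this change on its own, which leaves the estimate poorly anchored and its range wide. The expected step, a 1.5-fold higher number from compound 2 to compound 3 (0.19 log units; within the scatter), is a small rise that stays within the scatter. For compound 3, the expected half-life in this assay is 0.9 h, with an estimated range of 0.3 h to 2.5 h.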

Compound 3, half-life: 2.13 h
The estimate for compound 3 lay 2.4-fold (0.37 log units) below the measured number; the measured number falls inside the stated range.
By their numbers in this assay, from the lowest: compound 1; then compound 2; then compound 3.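

Within this assay the exchange of hydrogen for trifluoromethyl on a saturated chain carbon bound to an oxygen next to a carbonyl group and two saturated chain carbons gives a 3.7-fold higher number from compound 2 to compound 3 (0.56 log units; beyond the scatter) and so lies beyond the usual scatter. Unlike the gap between compound 1 and compound 2, which spans more than one place, this step belongs to a single change, isopropoxycarbonyl to (1-methyl-1-(trifluoromethyl)ethoxy)carbonyl, and it shows that the half-life responds to this position with the rest of the structure held constant. Nothing available explains why this change lengthens the half-life.

As far as these compounds go, it remains open whether the rise needs trifluoromethyl itself, or whether a difluoromethyl group or an ethyl group on this same carbon would give a step of similar size. Within the data shown here, with only one pair to read, it also remains open whether the same change would raise the half-life on a different structure, such as one carrying the other substituents of compound 1.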